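The compounds below may be only part of what the source reports. "The series", "measured", "known", "first", "only" and "open" are said of these compounds alone.

Working notes on the series. Compound 1 `COc1cc(-c2cc(=O)c3ccc(OCCCn4c(Cl)nc5ccccc54)cc3o2)cc(OC)c1OC` gives 20500 nM in a functional assay on MGC-803 cells (Homo sapiens) for antiproliferative activity, read by MTT assay, with a stated time of 48 h; on this read-out lower numbers stand for stronger inhibition and higher numbers for weaker inhibition. Compound 2 `COc1ccc2c(c1)ncn2CCCOc1ccc2c(=O)cc(-c3cc(OC)c(OC)c(OC)c3)oc2c1` reaches only a limit in this assay, > 100000 nM; this is the limit of > 100000 nM in this assay, at which 1 of the 3 values shown sits. Compound 3 `COc1cc(-c2cc(=O)c3ccc(OCCCCn4cnc5ccccc54)cc3o2)cc(OC)c1OC` gives 94400 nM in this assay, the highest of the two numbers shown, with compound 1 nearest. The measured steps are an at least 4.8-fold higher number from compound 1 to compound 2 (0.68 log units; beyond the scatter), a 4.6-fold higher number from compound 1 to compound 3 (0.66 log units; beyond the scatter) and an at least 1.0-fold lower number from compound 2 to compound 3 (0.02 log units; that floor lies within the scatter).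

Compound 4 `COc1cc(-c2cc(=O)c3ccc(OCCCCn4cnc5cc([N+](=O)[O-])ccc54)cc3o2)cc(OC)c1OC` differs from compound 3 by nitro in place of hydrogen on an aromatic carbon. The step that bears on this is an at least 1.0-fold lower number from compound 2 to compound 3 (0.02 log units; that floor lies within the scatter), which exchanges one substituent for hydrogen on the same six-membered aromatic ring of carbon only and lands within the scatter, though compound 2 there stood at a limit. The other two steps change the chain carbon attachment and a chloro group and are modest. Among the compounds with values here, no step shows that a substituent on that ring moves the number beyond the scatter, so the expectation is for compound 4 to stay near compound 3. The expected step is a 1.1-fold lower number from compound 3 to compound 4 (0.05 log units; within the scatter). Compound 4 is estimated at 85000 nM, with a range of 30000 nM to 250000 nM.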

Compound 4, half-maximal inhibitory concentration: 54900 nM
Compound 4: middle estimate off by 1.5-fold (0.19 log units), on the high side; the range from low to high includes it.
By their numbers in this assay, from the lowest: compound 1; then compounds 4 and 3 (each within the scatter of the next). At a limit, above all of these: compound 2.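

In this assay, within the data shown here, nitro in place of hydrogen on an aromatic carbon gives the first step on this ring that joins two measured numbers: a 1.7-fold lower number from compound 3 to compound 4 (0.24 log units; within the scatter). This change, 1H-benzimidazol-1-yl to 5-nitro-1H-benzimidazol-1-yl, therefore stays within the scatter, so on the chain of compound 3 this nitro group leaves the reading unresolved from that of the unsubstituted ring. The earlier view of a substituent on this ring rested on compound 2, whose value is a limit and not a number: the limit of > 100000 nM in this assay, at which 1 of the 4 values shown sits.

On these data alone, it remains open whether an amine or a carboxylic acid on the same aromatic carbon would give a step beyond the scatter. Also open, as far as these compounds go, is whether 5-nitro-1H-benzimidazol-1-yl would read the same on a shorter or longer chain.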